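What Losing the Vinyl Group Might Cost

A few compounds are considered here, and "the series" means these few. Any claim that something is new, unique, unknown or untested is made for them only; others in the source may bear on it.

Compound 1 `C=CC1C(=O)N(c2cc(OC)c(OC)c(OC)c2)C1c1ccc(OC)cc1` gives the lowest of the two numbers recorded so far, with a half-maximal inhibitory concentration of 33 nM in a functional assay on HL-60 cells (Homo sapiens) for inhibition, read by resazurin assay, with a stated time of 72 h; on this read-out lower numbers stand for stronger inhibition and higher numbers for weaker inhibition. Its nearest neighbour, compound 2 `C=CC1C(=O)N(c2cc(OC)c(OC)c(OC)c2)C1c1ccc(OCC)cc1`, gives 35 nM; the step of a 1.1-fold higher number from compound 1 to compound 2 (0.03 log units; within the scatter) shows that a methyl in place of hydrogen on a saturated chain carbon bound to an oxygen on an aromatic ring leaves the read-out essentially unchanged.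

Compound 3 `COc1ccc(C2CC(=O)N2c2cc(OC)c(OC)c(OC)c2)cc1` differs from compound 1 in another part of the shared core: hydrogen in place of vinyl on a saturated ring carbon. Within the data shown here, the one measured step concerns the alkoxy substituent on the aryl ring and says nothing about the saturated ring carbon, so no measured step bears directly on this change. With a whole group lost from the four-membered non-aromatic ring with 1 nitrogen, the account expects a higher number for compound 3, but with broad uncertainty, the expected step being a 6.1-fold higher number from compound 1 to compound 3 (0.78 log units; beyond the scatter). The estimate for compound 3 is therefore 200 nM, within a range from 40 nM to 1500 nM.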

Compound 3, half-maximal inhibitory concentration: 76 nM
Compound 3: middle estimate off by 2.6-fold (0.42 log units), on the high side, within the range that was stated.
By their numbers in this assay, from the lowest: compounds 1 and 2 (each within the scatter of the next); then compound 3.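

In this assay, among these compounds, this saturated ring carbon of the shared core gives the first step beyond the scatter: removing vinyl produces a 2.3-fold higher number from compound 1 to compound 3 (0.36 log units; beyond the scatter). The earlier alkoxy change, a 1.1-fold higher number from compound 1 to compound 2 (0.03 log units; within the scatter), had stayed within the scatter, so the vinyl position responds to change in a way that the alkoxy chain did not, although the step is only modest. Compound 3 still gives 76 nM with hydrogen at this position, which shows that much of the inhibition remains without vinyl, while nothing in the data explains why the number rises.

On these data alone, whether the rise follows the loss of the double bond or the loss of the two carbons stays open, as does whether ethyl, which would keep those carbons without the double bond, or aminomethyl on the same saturated ring carbon would bring the number back towards that of compound 1. The compounds shown also leave open whether the swap from methoxy to ethoxy would remain as silent in a compound carrying hydrogen rather than vinyl at this position.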